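The source may report more compounds than this note shows. Statements on the series, on what has been measured and on what is new or still open speak of the compounds shown alone.

Of the compounds shown here, three built on one shared core have been tested in a functional assay on L1210 cells (Mus musculus), with a stated time of 12 days; a lower number here means a less potent compound, a higher number a more potent compound, by a factor of ten per unit of this negative logarithm. Compound 1 `CC1=C(N2CC2)C(=O)C(CC(C)OC(N)=O)=C(N2CC2)C1=O` gives 6.14, compound 3 `CCOC(COC(N)=O)C1=C(N2CC2)C(=O)C(C)=C(N2CC2)C1=O` gives 6.18, and compound 2 `CC1=C(N2CC2)C(=O)C(Cc2ccccc2)=C(N2CC2)C1=O` gives 4.85. Compound 2 therefore stands lowest of the three: compound 1 is nearest and compound 3 furthest, and both gaps lie beyond the scatter. For the measured compounds named here, the only single-place step measured so far is a number 1.29 log units lower from compound 1 to compound 2 (beyond the scatter), a large drop when a benzyl group took the place of a chain without a ring. Compound 4 `CC1=C(N2CC2)C(=O)C(C(C)COC(N)=O)=C(N2CC2)C1=O` makes nearly the reverse move from compound 2: a group of 7 heavy atoms (4 carbon, 1 nitrogen, 2 oxygen; no ring) in place of a group of 7 heavy atoms (7 carbon; one six-membered aromatic ring of carbon only), on a double-bonded ring carbon. The benzyl group leaves and a chain without a ring enters on the core. Because the step of a number 1.29 log units lower from compound 1 to compound 2 (beyond the scatter) was large, the return of such a chain is expected to lift the read-out by about as much, so the estimated step is a number 1.25 log units higher from compound 2 to compound 4 (beyond the scatter). Compound 4 is thus expected to reach 6.1, within a range from 5.6 to 6.6. Compound 3, with its 6.18, points the same way.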

Compound 4, logarithm of the reciprocal of the active concentration, log(1/C): 6.41
Estimate against measurement, compound 4: 0.31 log units below, and the stated range covers the measured number.
By their numbers in this assay, from the lowest: compound 2; then compounds 1, 3 and 4 (each within the scatter of the next).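

In this assay, for the compounds shown here, exchanging benzyl for a chain without a ring on the double-bonded ring carbon gives a number 1.56 log units higher from compound 2 to compound 4 (beyond the scatter), so the large gap to benzyl now appears with a second chain and not only with the one in compound 1. Two chains of the same atom make-up give a number 0.27 log units higher from compound 1 to compound 4 (within the scatter), and methyl in place of ethoxy on the saturated chain carbon gives a number 0.23 log units higher from compound 3 to compound 4 (within the scatter), so neither change separates these compounds, and the chain tolerates both differences. No measurement at hand explains why benzyl stands apart.

On these data alone, all three chains compared with benzyl carry nitrogen and oxygen, so it remains open whether a plain propyl chain of carbon alone would stand with benzyl or with compound 4. As far as these compounds go, how an amine or a carboxylic acid in the chain would fare is also open.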